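Methoxy count on the aryl ring and paw edema inhibition

This account rests on a few compounds, and the source may have more. Where it says the series, first, only, none or still open, it means among the compounds named here.

Measured compounds:
Compound 1, `CCn1c(SCC(=O)c2ccccc2)nnc1-c1ccc(OC)cc1`, gives 61% in a functional assay on the whole organism (strain albino) for inhibition, with Rattus norvegicus as the target, read by paw edema, with a stated time of 5 h, at a dose of 0.28 mmol/kg by the oral route; a lower number here means less inhibition, a higher number more inhibition at the dose given (going by the name of the read-out).
Compound 2, `COc1ccc(-c2nnc(SCC(=O)c3ccccc3)n2-c2ccccc2)cc1OC`, gives 59% in this assay.
Compound 3, `CCn1c(SCC(=O)c2ccccc2)nnc1-c1cc(OC)c(OC)c(OC)c1`, gives 59% in this assay.

Compound 3 stands level with compound 2 at the digits shown, and the number of compound 1 differs from both only by an amount that lies within the usual scatter of this kind of measurement. The three compounds therefore behave alike at the dose used, whether the aryl ring carries one methoxy group or three, and whether the shared core carries an ethyl or a phenyl group.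

Compound 4, `CCn1c(SCC(=O)c2ccccc2)nnc1-c1ccc(OC)c(OC)c1`, has not yet been measured in this assay. It differs from compound 3 in one place: hydrogen in place of methoxy on an aromatic carbon

Because compound 1 with one methoxy group gives 61% and compound 3 with three gives 59%, no step beyond the scatter is expected in this assay, and the expected step from compound 3 to compound 4 is a number 1 percentage points higher from compound 3 to compound 4 (within the scatter). Compound 4 is estimated at 60%, within 48% to 72%.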

Compound 4, a percentage reported as inhibition, in the whole organism at one dose (the size of the read-out at that dose, not a potency): 69%
Estimate against measurement, compound 4: 9 percentage points below, within the range that was stated.
By their numbers in this assay, from the lowest: compounds 2, 3, 1 and 4 (each within the scatter of the next).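

Going by these compounds alone, compound 4 supplies the first steps that change only one place, and all of them stay within the usual scatter of this assay. Removing a methoxy group from the aromatic carbon gives a number 10 percentage points higher from compound 3 to compound 4 (within the scatter), adding one gives a number 8 percentage points higher from compound 1 to compound 4 (within the scatter), and putting ethyl in place of phenyl on the aromatic nitrogen gives a number 10 percentage points higher from compound 2 to compound 4 (within the scatter). At this dose, one, two or three methoxy groups on this ring cannot be told apart, nor can ethyl and phenyl on the two-methoxy ring, and nothing measured alongside these numbers offers an explanation.

Still open, on these data alone, is whether a hydroxyl group or an amine at this aromatic carbon, or a ring with no methoxy group at all, would stand apart from these compounds. As far as these compounds go, a propyl or longer chain on the nitrogen remains equally open.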